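From a Sulfur-Bearing Side Chain to Isopropyl

This account rests on a few compounds, and the source may have more. Where it says the series, first, only, none or still open, it means among the compounds named here.

Of the compounds shown here, two of one shared core have so far been tested in a functional assay on the whole organism (Tail, strain ICR) with Mus musculus as the target, in the tail flick test, with a stated time of 90 min, at a dose of 25 umol/kg by the oral route; a lower number here means a weaker effect, a higher number a stronger effect of the compound at the dose given. Compound 1 `O=C(O)C[C@H](NC(=O)CN(c1nc(Cl)nc2[nH]cnc12)C1CC1)C(=O)O` gives 25.1% in this assay, and compound 2 `CSCC[C@H](NC(=O)CN(c1nc(Cl)nc2[nH]cnc12)C1CC1)C(=O)O` gives 14%. For the measured compounds named here, compound 2 therefore stands lowest of the two numbers; the single measured step, a number 11.1 percentage points lower from compound 1 to compound 2 (beyond the scatter), sets it apart from compound 1, so its effect at the tested dose is the weaker of the two.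

Compound 3 `CC(C)[C@H](NC(=O)CN(c1nc(Cl)nc2[nH]cnc12)C1CC1)C(=O)O` has not yet been measured. It differs from compound 2 in one place: isopropyl in place of 2-(methylsulfanyl)ethyl on a saturated chain carbon bound to an amide-type nitrogen and a carbonyl carbon.

Going by the values given here, the only known step bears on this change loosely at most: it exchanged a carboxy for a (methylsulfanyl)methyl group and cost a modest amount of effect, whereas the present change removes the sulfur-bearing chain altogether and puts in a plain isopropyl, both without charge or donor. No measurement speaks to that exchange directly, so the expectation is for no step beyond the scatter. Compound 3 is thus estimated to give about 16%, with a range from 5% to 30%. For compound 3 this means an expected step of a number 2 percentage points higher from compound 2 to compound 3 (within the scatter), small and uncertain in direction.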

Compound 3, a percentage reported as activity, at one dose (the size of the read-out at that dose, not a potency): 30.3%
Beside the measured number, compound 3's estimate is 14.3 percentage points below it; the whole stated range lies below it.
By their numbers in this assay, from the lowest: compound 2; then compounds 1 and 3 (each within the scatter of the next).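

In this assay, the saturated chain carbon bound to an amide-type nitrogen and a carbonyl carbon proves sensitive even to a choice between two groups with no net charge: isopropyl in place of 2-(methylsulfanyl)ethyl gives a number 16.3 percentage points higher from compound 2 to compound 3 (beyond the scatter) in this comparison. Isopropyl in place of carboxymethyl gives a number 5.2 percentage points higher from compound 1 to compound 3 (within the scatter) and so leaves compound 1 and compound 3 indistinguishable here, which shows that a side chain without a carboxy group can still match the read-out of compound 1. Compound 2 now stands apart from both other compounds by steps beyond the scatter, but nothing available explains why this sulfur-bearing chain gives the lowest read-out.

The three compounds cannot show whether the read-out depends on branching or on the sulfur atom, and an unbranched butyl chain or a 2-(methoxy)ethyl group would be needed to separate those two possibilities. How a benzyl group or a 4-aminobutyl chain would behave at this position also stays open, as does how any of these compounds would compare across a range of doses.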